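The source may hold more compounds than are shown below. What is called first, only, known or untested is meant among the compounds shown, and "the series" means these compounds.

Compound 2 `CCC(C)(C)Cc1c[nH]c(CCc2ccc(N3CCCC[C@@H]3c3nnn[nH]3)cc2)n1` carries a 1H-tetrazol-5-yl group on a saturated ring carbon, and in an assay on isolated protein for binding affinity to Bombesin receptor subtype-3 (Homo sapiens) (on this read-out higher numbers stand for weaker inhibition and lower numbers for stronger inhibition), compound 2 gives 6.2 nM. Among the measured compounds shown here, of the two numbers recorded so far this is the higher one, but its only neighbour, compound 1 `CCC(C)(C)Cc1c[nH]c(CCc2ccc(N3CCCC[C@@H]3C(=O)O)cc2)n1`, which in this assay gives 5.3 nM, sits so close that the pair cannot be ordered: the change a 1.2-fold higher number from compound 1 to compound 2 (0.07 log units; within the scatter) lies within the scatter. Compound 3 `CCC(C)(C)Cc1c[nH]c(CCc2ccc(N3CCCC[C@@H]3c3ncn[nH]3)cc2)n1` has not yet been measured. It differs from compound 2 in a single place: 1H-1,2,4-triazol-5-yl in place of 1H-tetrazol-5-yl on a saturated ring carbon. For the measured compounds named here, the one measured step that bears on this exchange is the replacement of carboxy by 1H-tetrazol-5-yl at the same saturated ring carbon, from compound 1 to compound 2, and that step stayed within the scatter. With the whole group at this position already swapped once without a clear effect, compound 3 is expected to show, at most, a small step in this assay. Compound 3 is therefore estimated at 9 nM, with a range from 3 nM to 30 nM. The step this implies, a 1.5-fold higher number from compound 2 to compound 3 (0.16 log units; within the scatter), is expected to remain close to the scatter.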

Compound 3, half-maximal inhibitory concentration: 26 nM
Compound 3: the middle estimate sits 2.9-fold (0.46 log units) below what was measured, within the range that was stated.
By their numbers in this assay, from the lowest: compounds 1 and 2 (each within the scatter of the next); then compound 3.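

At this saturated ring carbon, next to the ring nitrogen, the binding read-out in this assay does respond to the group carried: the exchange gives a 4.2-fold higher number from compound 2 to compound 3 (0.62 log units; beyond the scatter), whereas the earlier swap, a 1.2-fold higher number from compound 1 to compound 2 (0.07 log units; within the scatter), stayed within the scatter. The comparison with the carboxy compound points the same way, with a 4.9-fold higher number from compound 1 to compound 3 (0.69 log units; beyond the scatter), so among the three groups shown, 1H-1,2,4-triazol-5-yl is the one that stands apart, while the other two cannot be ordered. The tetrazole and the triazole have the same heavy-atom count, hydrogen-bond donor count and lack of net charge, and differ in composition (1 carbon and 4 nitrogen against 2 carbon and 3 nitrogen) and in hydrogen-bond acceptors (3 against 2), but nothing available here shows which of these differences goes with the step.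

The compounds shown leave open how this position would respond to a group such as a carboxamide, a hydroxymethyl group or a primary amine. They also leave open whether an isomeric triazole, with its ring nitrogens placed differently, would follow the 1H-1,2,4-triazol-5-yl compound or stay with the tetrazole and carboxy compounds.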